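This account rests on a few compounds, and the source may have more. Where it says the series, first, only, none or still open, it means among the compounds named here.

Compound 1 `COc1ccc2c(C(=O)Nc3cc(F)cc(F)c3)cc(=O)[nH]c2n1` and compound 2 `CC(=O)c1ccc(-c2ccc3c(C(=O)Nc4cccc(F)c4)cc(=O)[nH]c3c2)cc1` share one core. In a functional assay on KYSE-70 cells for antiproliferative activity against KYSE-70 cell line (Homo sapiens), read by MTT assay, with a stated time of 72 h (a higher number here means a weaker inhibitor, a lower number a stronger inhibitor), compound 1 gives > 20000 nM, a limit of the assay rather than a number. In this assay compound 2 gives > 20000 nM, again only a limit. On the numbers shown compound 2 therefore stands at the limit of > 20000 nM in this assay, at which 2 of the 2 values shown sit, no lower than compound 1. Compound 3 `C=Cc1ccc2c(C(=O)Nc3cccc(F)c3)cc(=O)[nH]c2c1` differs from compound 2 in one place: vinyl in place of 4-acetylphenyl on an aromatic carbon. Going by the values given here, no measured step between compounds guides this change. Given (the limit of > 20000 nM in this assay, at which 2 of the 2 values shown sit), the step from compound 2 to compound 3 in this assay is expected to be a step that the limit leaves unreadable from compound 2 to compound 3, nothing beyond the scatter. For compound 3 the expected value is 25000 nM, within 6000 nM to 60000 nM.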

Compound 3, half-maximal inhibitory concentration: 9700 nM
For compound 3 the middle estimate is 2.6-fold (0.41 log units) above the measured one, within the range that was stated.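

In this assay vinyl in place of 4-acetylphenyl gives an at least 2.0-fold lower number from compound 2 to compound 3 (0.31 log units; beyond the scatter) at this position, so the group on this aromatic carbon can move the read-out. Compound 3 is the only one of the three shown that gives a number rather than a limit. The full size of the step stays unread, because the value for compound 2 is a limit: the limit of > 20000 nM in this assay, at which 2 of the 3 values shown sit.

As far as these compounds go, whether the vinyl double bond matters, or only the loss of the 4-acetylphenyl ring, stays open. An ethyl group or an aminomethyl group on this carbon would separate the two.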